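Swapping nitrile for fluorine on the pendant phenyl ring

The source may report more compounds than this note shows. Statements on the series, on what has been measured and on what is new or still open speak of the compounds shown alone.

Of the compounds shown here, three sharing one core have been measured in an in vitro functional assay on cells for antagonist activity at transient receptor potential cation channel subfamily V member 1 (Homo sapiens), read by FLIPR and calcium flux; a higher number here means a weaker inhibitor, a lower number a stronger inhibitor. Compound 1 `CCc1nc(Nc2cccc3c2CC(O)CC3)oc1-c1ccc(C(F)(F)F)cc1` gives 2.1 nM, compound 2 `CC(C)c1nc(Nc2cccc3c2CC(O)CC3)oc1-c1ccc(C(F)(F)F)cc1` gives 114 nM, and compound 3 `N#Cc1ccc(-c2nc(Nc3cccc4c3CC(O)CC4)oc2-c2ccc(C(F)(F)F)cc2)cc1` gives 2 nM. Compound 3 has the lowest number of the three, but the difference to compound 1 is within the scatter, while a 57-fold lower number from compound 2 to compound 3 (1.76 log units; beyond the scatter) is large. Compound 4 `OC1CCc2cccc(Nc3nc(-c4ccc(F)cc4)c(-c4ccc(C(F)(F)F)cc4)o3)c2C1` differs from compound 3 by fluoro in place of cyano on an aromatic carbon, the substituent sitting para to a large group. Among the compounds with values here, no measured step exchanges cyano for fluoro at this place. Within the data shown here, the only step that touches this part of the molecule is a 1.1-fold lower number from compound 1 to compound 3 (0.02 log units; within the scatter), which stayed within the scatter, and the large step of a 54-fold higher number from compound 1 to compound 2 (1.73 log units; beyond the scatter) lies elsewhere on the core. Among the measured compounds shown here, with no step pointing either way, compound 4 is expected to stay close to compound 3, with no step beyond the scatter. Compound 4 is therefore estimated at 3 nM, with a range from 1 nM to 12 nM. This expectation amounts to a 1.5-fold higher number from compound 3 to compound 4 (0.18 log units; within the scatter).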

Compound 4, half-maximal inhibitory concentration: 1.3 nM
For compound 4 the middle estimate is 2.3-fold (0.36 log units) above the measured one; low and high end bracket the measured number.
By their numbers in this assay, from the lowest: compounds 4, 3 and 1 (each within the scatter of the next); then compound 2.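

In this assay, the nitrile can give way to fluoro on the pendant phenyl ring, losing its triple bond and its hydrogen-bond acceptor, with the change staying within the scatter (a 1.5-fold lower number from compound 3 to compound 4 (0.19 log units; within the scatter)). The 4-fluorophenyl compound also sits within the scatter of the ethyl compound (a 1.6-fold lower number from compound 1 to compound 4 (0.21 log units; within the scatter)), so two different 4-substituted phenyl groups and ethyl all match at this place, while isopropyl stands apart as the exception (an 88-fold lower number from compound 2 to compound 4 (1.94 log units; beyond the scatter)). No measurement here explains why these groups match or why isopropyl differs.

Still open, from the compounds shown here alone, is whether this tolerance extends to a 4-aminophenyl or 4-carboxyphenyl group, or to a phenyl ring with no substituent. A longer chain such as n-propyl would show whether ethyl and isopropyl differ through chain length or through branching.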